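The source may report more compounds than this note shows. Statements on the series, on what has been measured and on what is new or still open speak of the compounds shown alone.

Working notes on the series, all members sharing one core. In an ADME assay on MDBK cells (Bos taurus) for cytotoxicity, read by MTT assay, with a stated time of 96 h (on this read-out higher numbers stand for lower toxicity in this test and lower numbers for higher toxicity in this test), compound 1 (`CC(=O)c1ccc2c(c1)nc(-c1ccccc1)n2C1CCCCC1`) gives > 100000 nM, which is a limit of the assay. Compound 2 (`COc1ccc(-c2nc3cc(C(C)=O)ccc3n2C2CCCCC2)cc1`) gives > 100000 nM, again a limit. Compound 3 (`CC(=O)c1ccc2c(c1)nc(-c1ccoc1)n2C1CCCCC1`) gives > 100000 nM, also a limit and not a number. Among the compounds with values here, the series so far stands at the limit of > 100000 nM in this assay, at which 3 of the 3 values shown sit.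

Compound 4 (`CC(=O)c1ccc2c(c1)nc(-c1ccccn1)n2C1CCCCC1`) carries pyridin-2-yl in place of the furan-3-yl of compound 3 on an aromatic carbon: pyridin-2-yl in place of furan-3-yl on an aromatic carbon.

Bearing on this are a step that the two limits leave unreadable from compound 1 to compound 3 and a step that the two limits leave unreadable from compound 2 to compound 3, along with a step that the two limits leave unreadable from compound 1 to compound 2. None of these has a readable size, so no direction of change is expected in this assay. The expected outcome is a number no higher from compound 3 to compound 4 (the limit leaves the size open), none beyond the scatter. For compound 4 the estimate is 100000 nM, with an expected range of 40000 nM to 100000 nM.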

Compound 4, half-maximal cytotoxic concentration: > 100000 nM
Compound 4 gave a limit, no number; the forecaster's own chance of this, stated with the estimate: 80%; the middle value lies on the limit itself.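

No step from compound 4 to compound 1, compound 2 or compound 3 can be read, since all four compounds sit at one limit: the limit of > 100000 nM in this assay, at which 4 of the 4 values shown sit.

The compounds shown leave open how far each lies beyond that limit, and whether changing the group on this aromatic carbon alters the read-out at all.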